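Aryl swap on the triazole nitrogen in the spiro series

The source may report more compounds than this note shows. Statements on the series, on what has been measured and on what is new or still open speak of the compounds shown alone.

Compound 2 `N#CC1=C(N)Oc2c(N)cc3nc4ccccc4nc3c2C12C(=O)N(Cc1cnnn1-c1ccc([N+](=O)[O-])cc1)c1ccccc12` stands at the limit of an ADME assay on HUVEC cells (Homo sapiens) for antiproliferative activity, read by MTT assay, with a stated time of 48 h; a lower number here means a stronger inhibitor, a higher number a weaker inhibitor: in this assay compound 2 gives > 50000 nM, a limit rather than a number. Compound 1 `Cc1cccc(-n2nncc2CN2C(=O)C3(C(C#N)=C(N)Oc4c(N)cc5nc6ccccc6nc5c43)c3ccccc32)c1` likewise gives > 50000 nM, also a limit. The step that the two limits leave unreadable from compound 1 to compound 2 is therefore unreadable. Compound 3 `N#CC1=C(N)Oc2c(N)cc3nc4ccccc4nc3c2C12C(=O)N(Cc1cnnn1-c1ccc(Cl)cc1Cl)c1ccccc12` carries 2,4-dichlorophenyl in place of 4-nitrophenyl on an aromatic nitrogen. Going by the values given here, the single measured step concerns the same aromatic nitrogen, and both of its values rest on (the limit of > 50000 nM in this assay, at which 2 of the 2 values shown sit), so it gives no direction and no size. For compound 3 a further limit is expected, the step of a number no higher from compound 2 to compound 3 (the limit leaves the size open) being estimated to stay within the scatter. Compound 3 is estimated at 50000 nM, between 20000 nM and 120000 nM.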

Compound 3, half-maximal inhibitory concentration: > 50000 nM
Compound 3 ended at the assay's limit (the forecaster's own chance of this, stated with the estimate: 85%); the middle value lies on the limit itself.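

Going by these compounds alone, no step between compound 1, compound 2 and compound 3 can be read in this assay, as all three values are limits: the limit of > 50000 nM in this assay, at which 3 of the 3 values shown sit.
Going by these compounds, whether any aryl group on this aromatic nitrogen changes the result in this assay stays open.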